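The compounds below may be only part of what the source reports. "The series", "measured", "known", "first", "only" and "open" are said of these compounds alone.

Compound 1, `C[C@H](Nc1ncnc(N)c1C#N)c1cc(=O)n2cc(F)ccc2c1-c1cc(F)cc(F)c1`: 57%
Compound 2, `C[C@H](Nc1nc(N)nc(N)c1C#N)c1cc(=O)n2cc(F)ccc2c1-c1cc(F)cc(F)c1`: 90%
Compound 3, `C[C@H](Nc1ncnc(N)c1C#N)c1c(C2CC2)c(=O)n2cc(F)ccc2c1-c1ccc(F)cc1`: 52%

These three compounds were measured in an ADME assay on microsomes from liver (Mus musculus), read by LC-MS, using NADPH, with a stated time of 30 min, tested at 1 uM; a higher number here means that more of the compound is left, a lower number that less of the compound is left. Compound 1 gives 57% and compound 2 gives 90%. The two differ by one change, (amino in place of hydrogen on an aromatic carbon), and that change made a step of a number 33 percentage points higher from compound 1 to compound 2 (beyond the scatter). Compound 3 gives 52%; its value and that of compound 1 lie within the scatter of each other, and it stands well under compound 2. How the core of compound 3 differs from the core of compound 1 is not broken down here.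

Compound 4, `C[C@H](Nc1nc(N)nc(N)c1C#N)c1c(C2CC2)c(=O)n2cc(F)ccc2c1-c1ccc(F)cc1`, has not yet been measured in this assay. It stands to compound 3 as compound 2 stands to compound 1: the change is amino in place of hydrogen on an aromatic carbon, and the place of the change reads word for word as it does for the pair of compound 1 and compound 2, so it is the same change. Going by the values given here, for compound 4 a step of a number 28 percentage points higher from compound 3 to compound 4 (beyond the scatter) is expected, because the one earlier instance of this change gave a number 33 percentage points higher from compound 1 to compound 2 (beyond the scatter). The expectation rests on a single pair, and the read-out cannot rise without bound, so the step is expected to be somewhat smaller than the earlier one. For compound 4 a value of 80% is estimated in this assay, between 62% and 95%.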

Compound 4, percent of the compound remaining: 75%
Compound 4: middle estimate off by 5 percentage points, on the high side; low and high end bracket the measured number.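

In this assay, amino in place of hydrogen on an aromatic carbon brought a number 23 percentage points higher from compound 3 to compound 4 (beyond the scatter), so on the core of compound 3 the change again moved the read-out in the same direction and beyond the scatter. Set side by side, the two steps cannot be told apart, and the change carried over from one core to the other with no size difference that these data can resolve: the same change on two cores in this assay, a number 33 percentage points higher (beyond the scatter) from compound 1 to compound 2 and a number 23 percentage points higher (beyond the scatter) from compound 3 to compound 4, 10 percentage points apart, within the scatter of two such steps

This rests on two cores only, which differ from each other in more than one place, so it shows no general rule for the series, does not tell which feature of the core, if any, bears on the size of the step, and gives no reason why the change acts as it does.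

The compounds shown leave open whether a methylamino or a methyl group on the same aromatic carbon, between two ring nitrogen atoms, would act as the amino group does. They also leave open whether the step would hold with a carboxamide in place of the cyano group, since all four compounds carry the cyano group.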